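Tert-butyl in Place of Methyl: Compound 4 Awaits Measurement

The compounds below may be only part of what the source reports. "The series", "measured", "known", "first", "only" and "open" are said of these compounds alone.

Measured compounds:
- compound 1 `CCN1CCc2c(c(C)nn2C(=O)Nc2ccc(Br)cc2)C1`: 1.7%
- compound 2 `CCN1CCc2c(c(C)nn2C(=O)Nc2cc(C)ccc2C)C1`: 2.6%
- compound 3 `CCN1CCc2c(c(C)nn2C(=O)Nc2ccc(Cl)cc2)C1`: 1.7%

Of the compounds shown here, three sharing one core have been tested in a functional assay on the whole organism (strain Swiss albino) for inhibition, with Mus musculus as the target, in the formalin test, with stated times of 30 min and 5 min, at a dose of 100 mg/kg; on this read-out lower numbers stand for less inhibition and higher numbers for more inhibition at the one dose given (going by the name of the read-out). Within the data shown here, compound 1 gives 1.7% in this assay, and compound 3 gives 1.7%; the step of no change at the digits printed from compound 1 to compound 3 (within the scatter) is the only single-point change among the measured pairs. Compound 2 gives 2.6%, which also lies within the scatter of compound 1. Compound 1 therefore stands level with compound 3 and with compound 2: all three numbers sit in the same narrow low band.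

Compound 4 `CCN1CCc2c(c(C(C)(C)C)nn2C(=O)Nc2ccc(Br)cc2)C1` differs from compound 1 by tert-butyl in place of methyl on an aromatic carbon. Among the measured compounds shown here, none of the measured steps touches this position or this kind of group, so nothing measured bears directly on it. For the measured compounds named here, the one measured step, from compound 1 to compound 3, was flat, and every number is small. Compound 4 is therefore expected to show a step of a number 0.8 percentage points higher from compound 1 to compound 4 (within the scatter), that is, none beyond the scatter. Compound 4 is estimated at 2.5%, with a range from 0% to 12%.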

Compound 4, a percentage reported as inhibition, in the whole organism at one dose (the size of the read-out at that dose, not a potency): 0%
The estimate for compound 4 lay 2.5 percentage points above the measured number; the measured number falls inside the stated range.
By their numbers in this assay, from the lowest: compounds 4, 1, 3 and 2 (each within the scatter of the next).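

In this assay tert-butyl in place of methyl on an aromatic carbon of the five-membered ring gives a number 1.7 percentage points lower from compound 1 to compound 4 (within the scatter) and so leaves compound 4 in the same low band as the other compounds. Among these compounds, the earlier step exchanged only chloro for bromo, so this is the first sign that enlarging the group at this second place, from one heavy atom to four, also moves the read-out by no more than the scatter. Nothing available accounts for this flat result, and with every number this low it cannot show how much this place matters.

What the compounds shown leave open is whether any group here can lift the read-out out of this band. From the compounds shown here alone, an amine or a carboxylic acid at this place remains untested among them, as does a longer chain such as n-butyl.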